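Chloro in place of fluoro on the phenoxy ring

This account rests on a few compounds, and the source may have more. Where it says the series, first, only, none or still open, it means among the compounds named here.

Measured so far:
- compound 1, `CCN1CCN(c2ccc(S(=O)(=O)Oc3cccc(F)c3)cc2)C1=O`: 11000 nM
- compound 2, `CCN1CCN(c2ccc(S(=O)(=O)Oc3cccc(Cl)c3)cc2)C1=O`: 3900 nM
- compound 3, `CCCN1CCN(c2ccc(S(=O)(=O)Oc3ccc(F)cc3)cc2)C1=O`: 14000 nM

In a functional assay on M21 cells (Homo sapiens) for antiproliferative activity, read by sulforhodamine B assay, with a stated time of 48 h (on this read-out higher numbers stand for weaker inhibition and lower numbers for stronger inhibition), compound 1 and compound 2 differ by chloro in place of fluoro on an aromatic carbon and the step is a 2.8-fold lower number from compound 1 to compound 2 (0.45 log units; beyond the scatter). The difference between the core of compound 1 and the core of compound 3 is not broken down here; in this assay compound 3 gives 14000 nM, a number within the scatter of compound 1.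

Compound 4, `CCCN1CCN(c2ccc(S(=O)(=O)Oc3ccc(Cl)cc3)cc2)C1=O`, differs from compound 3 by chloro in place of fluoro on an aromatic carbon. This is the same kind of change as that from compound 1 to compound 2, but the place differs: there the chloro sits meta to a large group, here para to a large group. A similar step is expected, a 2.8-fold lower number from compound 3 to compound 4 (0.45 log units; beyond the scatter), resting on a 2.8-fold lower number from compound 1 to compound 2 (0.45 log units; beyond the scatter). Compound 4 is estimated at 5000 nM, between 2500 nM and 10000 nM.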

Compound 4, half-maximal inhibitory concentration: 34000 nM
The estimate for compound 4 lay 6.8-fold (0.83 log units) below the measured number, outside the stated range (above it).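

In this assay, chloro in place of fluoro gives a 2.4-fold higher number from compound 3 to compound 4 (0.39 log units; beyond the scatter), so the earlier gain does not carry over to the core of compound 3. The two steps differ: the same change on two cores in this assay, a 2.8-fold lower number (0.45 log units; beyond the scatter) from compound 1 to compound 2 and a 2.4-fold higher number (0.39 log units; beyond the scatter) from compound 3 to compound 4, 6.8-fold (0.84 log units) apart, beyond the scatter of two such steps

This shows that neither the size nor the direction of the step can be assumed from one of these pairs to the other, but it does not show what sets them apart, as both the chain and the place of the halogen change between the pairs. The compounds shown leave open which of these two differences goes with the reversal, as no pair here varies only one of them. Also open, from the compounds shown here alone, is how bromo on the phenoxy ring or a butyl chain on the shared core would behave.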